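Replacing a halogenated phenyl with a methoxyphenyl

The source may report more compounds than this note shows. Statements on the series, on what has been measured and on what is new or still open speak of the compounds shown alone.

Compound 1 `O=C(Nc1ccc(Oc2ccnc3[nH]ccc23)cc1)c1cn(-c2ccc(Cl)cc2)c2ccccc2c1=O`: 1590 nM in a functional assay on MCF7 cells (Homo sapiens) for inhibition, read by MTT assay, with a stated time of 72 h; a lower number here means a stronger inhibitor, a higher number a weaker inhibitor
Compound 2 `O=C(Nc1ccc(Oc2ccnc3[nH]ccc23)cc1)c1cn(-c2ccc(Br)cc2F)c2ccccc2c1=O`: "not determined" (no result reported) in this assay

Compound 2 stands with no single number in this assay, its entry there being "not determined" (no result reported); only compound 1 carries a value there. Compound 3 `COc1ccc(-n2cc(C(=O)Nc3ccc(Oc4ccnc5[nH]ccc45)cc3)c(=O)c3ccccc32)cc1` differs from compound 2 by 4-methoxyphenyl in place of 4-bromo-2-fluorophenyl on an aromatic nitrogen. For the measured compounds named here, no pair of measured compounds that differ in one place is available, so the size of this step cannot be read from the data; the nearest comparison is compound 1, which gives 1590 nM in this assay. A step no larger than the usual scatter is expected in this assay. Compound 3 is estimated at 2000 nM, with an expected range of 500 nM to 8000 nM.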

Compound 3, half-maximal inhibitory concentration: 4650 nM
Beside the measured number, compound 3's estimate is 2.3-fold (0.37 log units) below it, within the range that was stated.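

Methoxy in place of chloro on the phenyl carried by the aromatic nitrogen gives a 2.9-fold higher number from compound 1 to compound 3 (0.47 log units; beyond the scatter) in this assay and so moves toward a weaker inhibitor. For the compounds shown here, this is the first readable step at this position, and it shows that the position is not indifferent to this change, although the step is modest. Nothing at hand accounts for the step. The step from compound 2 to compound 3 cannot be read. On these data alone, whether an amine or a carboxylic acid in place of the methoxy would move the number further, and in which direction, remains open.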